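The source may report more compounds than this note shows. Statements on the series, on what has been measured and on what is new or still open speak of the compounds shown alone.

For the measured compounds named here, compound 2, `CCOC(=O)c1[nH]c2cc(Cl)ccc2c1C(NCC1CCCCC1)c1nnnn1-c1ccc(Cl)cc1`, is the only compound in this set with a numerical result: in an assay for binding affinity to E3 ubiquitin-protein ligase Mdm2 (Homo sapiens), read by fluorescence polarization, with a stated time of 15 min (on this read-out higher numbers stand for weaker inhibition and lower numbers for stronger inhibition), compound 2 gives 117000 nM, a weak value. Compound 1, `CCCCCNC(c1c(C(=O)OCC)[nH]c2cc(Cl)ccc12)c1nnnn1-c1ccc(OCc2ccccc2Br)cc1`, which carries the (2-bromobenzyl)oxy group but a pentyl chain on the amine, was reported in this assay as "not active" (no number reported), without a number. Compound 3, `CCOC(=O)c1[nH]c2cc(Cl)ccc2c1C(NCC1CCCCC1)c1nnnn1-c1ccc(OCc2ccccc2Br)cc1`, has not yet been measured. It differs from compound 2 in one place: (2-bromobenzyl)oxy in place of chloro on an aromatic carbon. Going by the values given here, no step between two measured compounds is available to calibrate this change, so its effect rests on expectation alone. A step of a 1.1-fold higher number from compound 2 to compound 3 (0.05 log units; within the scatter) is expected, essentially none beyond the scatter, because compound 1 with the (2-bromobenzyl)oxy group gave "not active" (no number reported) as the only related result. Compound 3 is therefore estimated at 130000 nM, within a range from 30000 nM to 600000 nM, with a real chance that no number is obtained.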

Compound 3, inhibition constant: "not active" (no number reported)
No number was reported for compound 3; no gap can be computed for the estimate.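

For the compounds shown here, with compound 3 at "not active" (no number reported) in this assay, no step from compound 2 to compound 3 can be read. The compounds shown leave open how the (2-bromobenzyl)oxy group compares numerically with chloro on the shared core. No measured evidence bears on this result.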